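A few compounds are considered here, and "the series" means these few. Any claim that something is new, unique, unknown or untested is made for them only; others in the source may bear on it.

Measured so far, in an assay on isolated protein for inhibition of S-adenosylmethionine decarboxylase proenzyme (Homo sapiens); on this read-out higher numbers stand for weaker inhibition and lower numbers for stronger inhibition:
- compound 1 `CNc1nc2c(N)ncnc2n1[C@@H]1O[C@H](CN(C)CCCCON)[C@@H](O)[C@H]1O` gives 49 nM
- compound 2 `CN(CCC(=O)NN)C[C@H]1O[C@@H](n2cnc3c(N)ncnc32)[C@H](O)[C@@H]1O` gives 1500 nM
- compound 3 `CN(CCCN)C[C@H]1O[C@@H](n2cnc3c(N)ncnc32)[C@H](O)[C@@H]1O` gives 500000 nM

Compound 3 stands at the highest number of the three, which on this read-out means the weakest inhibition: compound 2 sits well below it, and compound 1 further still. Among the compounds with values here, the one measured step that bears on the end of the chain is a 330-fold higher number from compound 2 to compound 3 (2.52 log units; beyond the scatter), showing that what is carried at the end of this chain can move the number a great deal.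

Compound 4 `CN(CCCCON)C[C@H]1O[C@@H](n2cnc3c(N)ncnc32)[C@H](O)[C@@H]1O` is compound 3 with one change: (aminooxy)methyl in place of amino on a saturated chain carbon, three bonds along the chain from an amine nitrogen. This gives compound 4 the same chain end as compound 1, while its core is that of compound 3. Within the data shown here, no step between compound 1 and compound 4 is measured, so their two values can only be compared as numbers; compound 1 shows that this chain end sits with a low number on a related core.

Because the step of a 330-fold higher number from compound 2 to compound 3 (2.52 log units; beyond the scatter) was large, a large step in the opposite direction is expected here: compound 4 is estimated to give a 3300-fold lower number from compound 3 to compound 4 (3.52 log units; beyond the scatter) in this assay. The estimate for compound 4 is 150 nM, with a range from 30 nM to 1500 nM.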

Compound 4, half-maximal inhibitory concentration: 18 nM
For compound 4 the middle estimate is 8.3-fold (0.92 log units) above the measured one; the whole stated range lies above it.
By their numbers in this assay, from the lowest: compound 4; then compound 1; then compound 2; then compound 3.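

In this assay, (aminooxy)methyl in place of amino on a saturated chain carbon, three bonds along the chain from an amine nitrogen, gives a 28000-fold lower number from compound 3 to compound 4 (4.44 log units; beyond the scatter), so this chain end can turn a nearly inactive compound into a strong inhibitor on the same core. It also outperforms the chain end carrying the aminocarbamoyl group: 2-(aminooxy)ethyl in its place, on a saturated chain carbon two bonds along the chain from an amine nitrogen, gives an 83-fold lower number from compound 2 to compound 4 (1.92 log units; beyond the scatter). The methylamino group on the aromatic carbon of compound 1 proves unnecessary for strong inhibition, since hydrogen in its place gives a 2.7-fold lower number from compound 1 to compound 4 (0.43 log units; beyond the scatter), a modest step that is still beyond the scatter and tiny beside the change at the chain end.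

The step from compound 3 to compound 4 both lengthens the chain and adds the oxygen, so a 5-aminopentyl chain, with carbon where compound 4 has oxygen, would be needed to separate the two changes. Nothing available here explains why these steps are so large or why they run in these directions.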